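Methoxy to amino on a series stuck at the assay limit

A few compounds are considered here, and "the series" means these few. Any claim that something is new, unique, unknown or untested is made for them only; others in the source may bear on it.

Measured compounds:
Compound 1, `N#CC1=C(N)Oc2c(c3nc4ccccc4nc3c3ccccc23)C12C(=O)N(Cc1cnnn1-c1ccc(Br)cc1)c1ccccc12`, in a functional assay on HCT-116 cells (Homo sapiens) for antiproliferative activity, read by MTT assay, with a stated time of 48 h (on this read-out lower numbers stand for stronger inhibition and higher numbers for weaker inhibition), gives > 50000 nM, which is a limit of the assay rather than a number.
Compound 2, `N#CC1=C(N)Oc2c(c3nc4ccccc4nc3c3ccccc23)C12C(=O)N(Cc1cnnn1-c1cccc(Br)c1)c1ccccc12`, in this assay gives > 50000 nM, also a limit.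
Compound 3, `COc1ccc(-n2nncc2CN2C(=O)C3(C(C#N)=C(N)Oc4c3c3nc5ccccc5nc3c3ccccc43)c3ccccc32)cc1`, in this assay gives > 50000 nM, again a limit.

Among the measured compounds shown here, compound 3 therefore stands where every compound measured so far stands: at the limit of > 50000 nM in this assay, at which 3 of the 3 values shown sit. Because its value is a limit, it cannot be placed above or below compound 1 or compound 2; all three are simply unresolved at the top of the measurable range.

Compound 4, `N#CC1=C(N)Oc2c(c3nc4ccccc4nc3c3ccccc23)C12C(=O)N(Cc1cnnn1-c1ccc(N)cc1)c1ccccc12`, differs from compound 3 by amino in place of methoxy on an aromatic carbon. The measured steps that touch this same phenyl group on the aromatic nitrogen are a step that the two limits leave unreadable from compound 1 to compound 2, a step that the two limits leave unreadable from compound 1 to compound 3 and a step that the two limits leave unreadable from compound 2 to compound 3. Each of them joins two limits, so none has a readable size, and they give no direction for the change from methoxy to amino.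

With nothing in the measured steps pointing toward a gain, compound 4 is expected to stay at the limit as well, so the expected step is a number no higher from compound 3 to compound 4 (the limit leaves the size open). The estimate for compound 4 in this assay is 50000 nM, with a range from 15000 nM to 150000 nM.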

Compound 4, half-maximal inhibitory concentration: 45200 nM
For compound 4 the middle estimate is 1.1-fold (0.04 log units) above the measured one; measured number inside the range.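

Among the compounds shown here, with amino on the aromatic carbon para to a large group, compound 4 is the only compound here that gives a real number in this assay, so this position can yield a readable value and not just a limit. Compounds 1, 2 and 3 each remain at a limit of the assay: the limit of > 50000 nM in this assay, at which 3 of the 4 values shown sit. As far as these compounds go, as a result, each comparison with compound 4 sets only a floor, and the true size stays unknown: 4-methoxyphenyl to 4-aminophenyl gives an at least 1.1-fold lower number from compound 3 to compound 4 (0.04 log units; that floor lies within the scatter) and the change from the 3-bromophenyl group gives an at least 1.1-fold lower number from compound 2 to compound 4 (0.04 log units; that floor lies within the scatter) while amino in place of bromo gives an at least 1.1-fold lower number from compound 1 to compound 4 (0.04 log units; that floor lies within the scatter) and none of these floors shows a change beyond the usual scatter.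

The steps among compounds 1, 2 and 3 cannot be read, so these compounds say nothing about how methoxy and bromo rank or whether moving bromo on the ring matters. From the compounds shown here alone, it also remains open whether a readable value is specific to amino or would also appear with a hydroxyl, a methylamino or an acetamido group at the same place.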